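This account rests on a few compounds, and the source may have more. Where it says the series, first, only, none or still open, it means among the compounds named here.

For the measured compounds named here, compound 1 `CO[C@@H]1CN(CC2Cc3ccccc3C2)CC[C@H]1n1c(C)nc2cc(C)ccc21` sits at the top of the three numbers so far: in an assay on isolated protein for binding affinity to melanin-concentrating hormone receptor 1 (Homo sapiens) (a lower number here means a stronger inhibitor, a higher number a weaker inhibitor), compound 1 gives 47 nM. Compound 2 `CO[C@@H]1CN(C[C@@H]2Cc3ccc(NC(=O)C(C)C)cc3C2)CC[C@H]1n1c(C)nc2cc(C)ccc21` gives 31 nM in this assay, and compound 3 `CO[C@@H]1CN(C[C@H]2Cc3ccc(C#N)cc3C2)CC[C@H]1n1c(C(C)(C)O)nc2cc(C)ccc21` gives 3 nM. Compound 4 `COC(=O)Nc1ccc2c(c1)C[C@@H](CN1CC[C@@H](n3c(C)nc4cc(C)ccc43)[C@H](OC)C1)C2` differs from compound 1 by (methoxycarbonyl)amino in place of hydrogen on an aromatic carbon. Going by the values given here, the one measured step that bears on it is the change at the same aromatic carbon a 1.5-fold lower number from compound 1 to compound 2 (0.18 log units; within the scatter), which stayed inside the scatter; compound 3 carries two further changes and does not isolate this position. A step in this assay no larger than that, in either direction, is therefore expected, so compound 4 is estimated at 30 nM (range 12 nM to 75 nM), meaning an expected step of a 1.6-fold lower number from compound 1 to compound 4 (0.19 log units; within the scatter).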

Compound 4, inhibition constant: 20 nM
Compound 4: the middle estimate sits 1.5-fold (0.18 log units) above what was measured; the measured number falls inside the stated range.
By their numbers in this assay, from the lowest: compound 3; then compounds 4, 2 and 1 (each within the scatter of the next, the first and the last beyond it).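

In this assay, (methoxycarbonyl)amino on this aromatic carbon gives a 2.4-fold lower number from compound 1 to compound 4 (0.37 log units; beyond the scatter), a modest step but the first at this position to lie beyond the scatter. Compound 4 and compound 2 remain within the scatter of each other, so the two groups at this carbon cannot be ranked. Nothing on hand accounts for the step.

Still open, on these data alone, is whether a plain amine or a carboxylic acid on this carbon would keep the number. Also open, as far as these compounds go, is how (methoxycarbonyl)amino would read alongside the other place changed in compound 3.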